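The compounds below may be only part of what the source reports. "The series", "measured", "known", "first", "only" and "open" are said of these compounds alone.

Measured compounds and their values in a functional assay on HeLa cells (Homo sapiens) for cytotoxicity, read by CCK-8 assay, with a stated time of 72 h; on this read-out lower numbers stand for stronger inhibition and higher numbers for weaker inhibition:

compound 1 `COc1ccccc1/C=c1/[nH]c(=O)/c(=C\c2ccccc2OC)[nH]c1=O`: "not active" (no number reported)
compound 2 `C=CCn1c(=O)/c(=C\c2cccc(F)c2)[nH]c(=O)/c1=C\c1ccccc1OC`: 9100 nM
compound 3 `C=CCn1c(=O)/c(=C\c2ccccc2OC)[nH]c(=O)/c1=C\c1ccccc1OC`: 6900 nM

Compound 2 carries the highest of the two numbers reported, its nearest neighbour being compound 3, with a 1.3-fold lower number from compound 2 to compound 3 (0.12 log units; within the scatter); compound 1 stands apart without a number. For the measured compounds named here, the pair compound 2 and compound 3 is the only step that alters the group on the double-bonded chain carbon bound to an aromatic carbon, and that step did not leave the scatter.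

Compound 4 `C=CCn1c(=O)/c(=C\c2ccccc2F)[nH]c(=O)/c1=C\c1ccccc1OC` differs from compound 2 as follows: 2-fluorophenyl in place of 3-fluorophenyl on a double-bonded chain carbon bound to an aromatic carbon

Going by the values given here, no measured step moves a fluorine within the same ring, so the only guide is that the one change at this position, 2-methoxyphenyl for 3-fluorophenyl, gave a step inside the scatter. On that basis the expected step is a 1.1-fold lower number from compound 2 to compound 4 (0.03 log units; within the scatter), that is, none beyond the scatter. Compound 4 is therefore estimated at 8500 nM, with a range from 3000 nM to 25000 nM.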

Compound 4, half-maximal inhibitory concentration: 45000 nM
Compound 4: middle estimate off by 5.3-fold (0.72 log units), on the low side, and the stated range ends below it.
By their numbers in this assay, from the lowest: compounds 3 and 2 (each within the scatter of the next); then compound 4.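

In this assay, for the compounds shown here, this position is not indifferent to the place of the fluorine: with the same atoms joined differently, 2-fluorophenyl in place of 3-fluorophenyl gives a 4.9-fold higher number from compound 2 to compound 4 (0.69 log units; beyond the scatter), the first step at this position beyond the scatter. The group on the ring also counts, since fluoro in place of methoxy on an aromatic carbon gives a 6.5-fold higher number from compound 3 to compound 4 (0.81 log units; beyond the scatter), so the earlier close pair of compound 2 and compound 3 did not mean that changes here leave the number unmoved. No measured evidence accounts for either step.

The compounds shown leave open how far the number moves with a group other than fluoro or methoxy on this ring, such as an amine or a carboxylic acid. They also leave open whether a longer chain in place of the allyl group would change the number of compound 4.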